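Three pyrazole diesters and a methyl on the phenyl ring

A few compounds are considered here, and "the series" means these few. Any claim that something is new, unique, unknown or untested is made for them only; others in the source may bear on it.

Compound 1, `CCOC(=O)c1c(-c2c(Cl)c3ccccc3oc2=O)nn(-c2ccccc2)c1C(=O)OCC`: 48000 nM
Compound 2, `CCOC(=O)c1c(-c2c(Cl)c3cc(C)ccc3oc2=O)nn(-c2ccccc2)c1C(=O)OCC`: 50000 nM
Compound 3, `CCOC(=O)c1c(-c2cc3ccccc3oc2=O)nn(-c2ccccc2)c1C(=O)OCC`: 57000 nM

The three measured compounds share a pyrazole diester core carrying a phenyl ring and a fused bicyclic lactone, and all three were tested in a functional assay on DU-145 cells (Homo sapiens) for cytotoxicity, read by MTT assay, with a stated time of 48 h; on this read-out higher numbers stand for weaker inhibition and lower numbers for stronger inhibition. In this assay compound 1 gives 48000 nM, compound 2 gives 50000 nM and compound 3 gives 57000 nM. The three numbers sit close together, and neither change among them moves the read-out beyond the scatter of the assay: a 1.0-fold higher number from compound 1 to compound 2 (0.02 log units; within the scatter), with the difference (methyl in place of hydrogen on an aromatic carbon), and a 1.2-fold higher number from compound 1 to compound 3 (0.07 log units; within the scatter), with the difference (hydrogen in place of chloro on an aromatic carbon).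

Compound 4, `CCOC(=O)c1c(-c2cc3ccccc3oc2=O)nn(-c2cccc(C)c2)c1C(=O)OCC`, has not yet been measured. It differs from compound 3 by methyl in place of hydrogen on an aromatic carbon. Among the measured compounds shown here, this is the same kind of change as the one from compound 1 to compound 2, but not the same: there the methyl entered on a six-membered aromatic ring of carbon only that is part of a fused or bridged system of two rings, meta to a fused ring and para to a fused ring, whereas here it enters on a six-membered aromatic ring of carbon only, meta to a large group. The cores of compound 1 and compound 3 differ by hydrogen in place of chloro on an aromatic carbon.

Because a 1.0-fold higher number from compound 1 to compound 2 (0.02 log units; within the scatter) lay within the scatter, compound 4 is expected to show a 1.0-fold lower number from compound 3 to compound 4 (0.02 log units; within the scatter) in this assay. The estimated value for compound 4 is 55000 nM, with a likely range from 30000 nM to 100000 nM.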

Compound 4, half-maximal inhibitory concentration: 47000 nM
Compound 4: middle estimate off by 1.2-fold (0.07 log units), on the high side; low and high end bracket the measured number.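

In this assay, methyl in place of hydrogen on the phenyl ring gives a 1.2-fold lower number from compound 3 to compound 4 (0.08 log units; within the scatter), so this change leaves the read-out within the scatter on this core, as it did on the core of compound 1. Set side by side, the two steps do not differ: the same change on two cores in this assay, a 1.0-fold higher number (0.02 log units; within the scatter) from compound 1 to compound 2 and a 1.2-fold lower number (0.08 log units; within the scatter) from compound 3 to compound 4, 1.3-fold (0.10 log units) apart, within the scatter of two such steps This shows only that in these two pairs the added methyl moved the number by no more than the assay can resolve; it does not show that the change carries over as a rule, since only two cores are shown, the methyl sits on a different ring in each pair, and steps this small could hide a real but slight effect of either sign.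

The compounds shown leave open whether a different group on the phenyl ring, such as an amine, a carboxylic acid or a longer chain, would move the number beyond the scatter, and whether replacing the ethyl esters of the shared core with a carboxylic acid or an amide would do so. They also leave open how phenyl to 3-methylphenyl would read on the core of compound 1.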